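Compound 3 to its silyl-bearing analogue

The source may report more compounds than this note shows. Statements on the series, on what has been measured and on what is new or still open speak of the compounds shown alone.

In a functional assay on A549 cells (Homo sapiens) for cytotoxicity, read by MTT assay, with a stated time of 6 days (on this read-out lower numbers stand for an effect already at smaller amounts and higher numbers for an effect only at larger amounts of compound), compound 3 `Nc1ccc(-c2cc(=O)c3ccc(O)cc3o2)cc1` gives 8.87 ug/mL, the lower of the two actual numbers, and compound 2 `O=c1cc(-c2ccc([N+](=O)[O-])cc2)oc2cc(O)ccc12` gives 21.8 ug/mL. Compound 1 `COC(=O)c1c(-c2ccc(OC)cc2)oc2ccccc2c1=O` reaches only a limit, > 25 ug/mL.

Compound 4 `CC(C)(C)[Si](C)(C)Oc1ccc(-c2cc(=O)c3ccc(O)cc3o2)cc1` loses the amino group of compound 3 at the same aromatic carbon, para to a large group: a group of 8 heavy atoms (6 carbon, 1 oxygen, 1 silicon; no ring) in place of one nitrogen atom, on an aromatic carbon.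

Going by the values given here, only one measured step bears on this place: a 2.5-fold lower number from compound 2 to compound 3 (0.39 log units; beyond the scatter). It is modest, and it involves a different pair of groups, so it offers only loose guidance. Among the compounds with values here, with the amino group gone, the lower number seen in that step may not carry over, but no measured step covers the entering group. A small move towards a higher number in this assay is therefore expected, possibly not beyond the scatter. The expected step is a 1.5-fold higher number from compound 3 to compound 4 (0.17 log units; within the scatter). For compound 4 the estimate is 13 ug/mL, with an expected range of 5 ug/mL to 25 ug/mL.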

Compound 4, concentration for half-maximal effect: 6.45 ug/mL
The estimate for compound 4 lay 2.0-fold (0.30 log units) above the measured number, within the range that was stated.
By their numbers in this assay, from the lowest: compounds 4 and 3 (each within the scatter of the next); then compound 2. At a limit, above all of these: compound 1.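

In this assay, going by these compounds alone, the aromatic carbon para to a large group takes a far bigger group than the earlier compounds showed: the group of 8 heavy atoms with its silicon replaces amino with a 1.4-fold lower number from compound 3 to compound 4 (0.14 log units; within the scatter) and no hydrogen-bond donor remains on that group. Set against the nitro group, the same entering group gives a 3.4-fold lower number from compound 2 to compound 4 (0.53 log units; beyond the scatter) and so shows that the lower number relative to nitro does not depend on amino. No measurement shown here gives a cause for either step.

Open, on these data alone, is whether a hydroxyl or a methoxy group on this carbon would read with compound 3 and compound 4 or with compound 2. Also open, as far as these compounds go, is how a carboxylic acid or a plain longer chain would stand at the same place.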